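Antiproliferative series on a fused bicyclic amide core

The compounds below may be only part of what the source reports. "The series", "measured", "known", "first", "only" and "open" are said of these compounds alone.

Measured so far:
compound 1, `NC(=O)c1c(NC(=O)c2ccccc2Cl)sc2c1CCN(Cc1ccccc1Cl)C2`, 2900 nM
compound 2, `NC(=O)c1c(NC(=O)c2ccc(C(F)(F)F)cc2)sc2c1CCN(Cc1ccc(Cl)cc1Cl)C2`, 14900 nM
compound 3, `Cc1ccc(C(=O)Nc2sc3c(c2C(N)=O)CCN(Cc2c(Cl)cccc2Cl)C3)cc1`, 10000 nM

All three were run in a functional assay on HL-60 cells (Homo sapiens) for antiproliferative activity, with a stated time of 24 h; a lower number here means a stronger inhibitor, a higher number a weaker inhibitor. Among them, compound 1 stands at the lowest number; the nearest is compound 3, whose number is higher by an amount beyond the usual scatter, and the furthest is compound 2, whose number is higher still and also beyond the scatter. Within the data shown here, no single-point change between the measured compounds is available, so the series gives no measured step to lean on.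

Compound 4, `NC(=O)c1c(NC(=O)c2ccccc2Cl)sc2c1CCN(C(=S)Nc1ccccc1F)C2`, has not yet been measured. It differs from compound 1 as follows: a group of 10 heavy atoms (7 carbon, 1 nitrogen, 1 fluorine, 1 sulfur; one six-membered aromatic ring of carbon only) in place of a group of 8 heavy atoms (7 carbon, 1 chlorine; one six-membered aromatic ring of carbon only), on an amine nitrogen in a ring. Among the measured compounds shown here, the benzyl-type substituent on the ring amine nitrogen is thus exchanged for a group carrying a hydrogen-bond donor and acceptor, a change with no precedent among the three measured compounds.

For the measured compounds named here, with no measured step to guide the expectation, a modest shift toward a higher number is expected, of the size a 1.7-fold higher number from compound 1 to compound 4 (0.24 log units; within the scatter), though a result within the scatter of compound 1 would not be surprising. Compound 4 is estimated at 5000 nM, in the range 1500 nM to 20000 nM.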

Compound 4, half-maximal inhibitory concentration: 4970 nM
Compound 4: middle estimate off by 1.0-fold (0.00 log units), on the high side; measured number inside the range.
By their numbers in this assay, from the lowest: compounds 1, 4, 3 and 2 (each within the scatter of the next, the first and the last beyond it).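

In this assay, the amine nitrogen in the ring tolerates a large change of substituent: with the 2-chlorobenzyl group exchanged for a group that carries a hydrogen-bond donor and acceptor, the result is a 1.7-fold higher number from compound 1 to compound 4 (0.23 log units; within the scatter). For this pair, therefore, a benzyl group on this nitrogen is not needed to keep activity at the level of compound 1, and the added donor and acceptor bring no gain beyond the scatter. No measured property of either compound bears on why the exchange is tolerated.

From the compounds shown here alone, it remains open whether the sulfur of the entering group contributes anything, which the urea with oxygen in place of sulfur would test. A smaller acetyl group or a free amine on the same nitrogen would show how much of the aromatic substituent is needed at all.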